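Swapping a side chain: what compound 4 may do

The source may report more compounds than this note shows. Statements on the series, on what has been measured and on what is new or still open speak of the compounds shown alone.

Measured in an in vitro ADME assay on microsomes from liver (Homo sapiens) for metabolic stability, tested at 5 uM; a lower number here means that the compound disappears faster, a higher number that the compound lasts longer:
- Compound 1 `CC(C)CCn1nc(CC2=CCCC2)c(O)c(C2=NS(=O)(=O)c3cc(NS(C)(=O)=O)ccc3N2)c1=O`: 0.15 h
- Compound 2 `CS(=O)(=O)Nc1ccc2c(c1)S(=O)(=O)N=C(c1c(O)c(-c3cccs3)nn(CC3CCC3)c1=O)N2`: > 1 h (a limit)
- Compound 3 `COC(C)(C)CCn1nc(-c2cccs2)c(O)c(C2=NS(=O)(=O)c3cc(NS(C)(=O)=O)ccc3N2)c1=O`: > 1 h (a limit)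

Compound 3 gives > 1 h as a limit of the assay, not a number. Compound 4 `CS(=O)(=O)Nc1ccc2c(c1)S(=O)(=O)N=C(c1c(O)c(-c3cccs3)nn(CC3CC3)c1=O)N2` is not yet measured. The change is cyclopropyl in place of 2-methoxy-2-methylpropyl on a saturated chain carbon bound to an aromatic nitrogen and it turns 3-methoxy-3-methylbutyl into cyclopropylmethyl. Among the compounds with values here, the one measured step at this place is a step that the two limits leave unreadable from compound 2 to compound 3 and it offers no size to build on. Where compound 4 carries cyclopropyl, compound 2 carries cyclobutyl and gives > 1 h as a limit. Within the data shown here, no single-change step ties compound 1 to compound 4. The step expected in this assay is therefore none beyond the scatter, and the estimate is a step that the limit leaves unreadable from compound 3 to compound 4 with no firm direction. Compound 4 is expected at 1.2 h with an estimated range of 0.5 h to 2.5 h in this measure.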

Compound 4, half-life: > 1 h
Compound 4 ended at the assay's limit; the forecaster's own chance of this, stated with the estimate: 70%; the middle value lies beyond the limit too.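

In this assay compound 4 gives > 1 h, a limit and not a number, so no step linking compound 2, compound 3 and compound 4 can be read: the limit of > 1 h in this assay, at which 3 of the 4 values shown sit.

The compounds shown leave open how long compound 2, compound 3 and compound 4 really last, and whether their side chains make any difference.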